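A few compounds are considered here, and "the series" means these few. Any claim that something is new, unique, unknown or untested is made for them only; others in the source may bear on it.

Compound 1 `Nc1ccccc1NC(=O)CCCCCCc1nc(-c2ccccc2)no1` is the starting point of this short series. In an assay on isolated protein for inhibition of histone deacetylase 8 (Homo sapiens), read by fluorescence, with a stated time of 10 min (on this read-out higher numbers stand for weaker inhibition and lower numbers for stronger inhibition), compound 1 gives > 10000 nM, which is a limit of the assay rather than a measured number. Two close relatives share its core and differ only on the phenyl ring. Compound 2 `Nc1ccccc1NC(=O)CCCCCCc1nc(-c2ccc(Cl)cc2)no1` carries a chloro group in place of a hydrogen on that ring; in this assay compound 2 gives > 10000 nM, again a limit. Compound 3 `Nc1ccccc1NC(=O)CCCCCCc1nc(-c2cccc([N+](=O)[O-])c2)no1` carries a nitro group instead; in this assay compound 3 gives > 10000 nM, also a limit. The steps a step that the two limits leave unreadable from compound 1 to compound 2, a step that the two limits leave unreadable from compound 1 to compound 3 and a step that the two limits leave unreadable from compound 2 to compound 3 are therefore all unreadable, since (the limit of > 10000 nM in this assay, at which 3 of the 3 values shown sit).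

Compound 4 `O=C(CCCCCCc1nc(-c2ccccc2)no1)C(F)(F)F` changes a different part of the molecule: trifluoromethyl in place of (2-aminophenyl)amino on a carbonyl carbon. Among the measured compounds shown here, none of the measured steps touches this end of the structure, so they offer no guide to the size or direction of the change; they show only that every variation so far left the value at the limit. On that footing the expected value for compound 4 in this assay is estimated at 2000 nM, within a range from 300 nM to 15000 nM, with a real chance that only a limit is reported once more. This estimate means an expected step of an at least 5.0-fold lower number from compound 1 to compound 4 (0.69 log units; beyond the scatter).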

Compound 4, half-maximal inhibitory concentration: 760 nM
The estimate for compound 4 lay 2.6-fold (0.42 log units) above the measured number, and the stated range covers the measured number.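

In this assay, among the compounds shown here, putting trifluoromethyl in place of (2-aminophenyl)amino on the carbonyl carbon gives an at least 13-fold lower number from compound 1 to compound 4 (1.11 log units; beyond the scatter), the only step whose size can be read, and it lies beyond the usual scatter. On these data alone, compound 1 gives > 10000 nM, which is a limit and not a number, so the printed step is a minimum and its exact size stays unknown. The chloro and nitro changes on the phenyl ring in compound 2 and compound 3 left the value at the limit, whereas this change on the carbonyl carbon brought it off the limit, making this the only place shown so far to register in this assay: the limit of > 10000 nM in this assay, at which 3 of the 4 values shown sit.

The change removes a six-membered aromatic ring and two hydrogen-bond donors and brings in three fluorine atoms all at once, so the compounds shown cannot separate the loss of the old group from the arrival of the new one. As far as these compounds go, how a methyl group or a hydroxyamino group on the same carbonyl carbon would read remains open, as do the effects of a longer chain and of chloro or nitro on the phenyl ring with trifluoromethyl in place.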